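The source may hold more compounds than are shown below. What is called first, only, known or untested is meant among the compounds shown, and "the series" means these compounds.

Measured in a functional assay on U-87MG ATCC cells for inhibition, with U-87 MG (Homo sapiens) as the target, read by MTT assay, with a stated time of 72 h; on this read-out lower numbers stand for stronger inhibition and higher numbers for weaker inhibition:
- compound 1 `Oc1c(C(Nc2ccccn2)c2ccccc2F)ccc2cccnc12`: > 10000 nM, a limit
- compound 2 `Cc1ccc(C)c(C(Nc2ccccn2)c2ccc3cccnc3c2O)c1`: 13800 nM
- compound 3 `COc1ccc(C(Nc2cc(C)ccn2)c2ccc3cccnc3c2O)cc1O`: > 10000 nM, a limit

Among the compounds with values here, compound 2 holds the only actual number, 13800 nM. The other two results are limits: the limit of > 10000 nM in this assay, at which 2 of the 3 values shown sit.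

Compound 4 `Cc1cc(C)c(C(Nc2ccccn2)c2ccc3cccnc3c2O)c(C)c1` carries 2,4,6-trimethylphenyl in place of 2,5-dimethylphenyl on a saturated chain carbon bound to an aromatic carbon and a nitrogen on an aromatic ring.

Within the data shown here, the one measured step at this place is a step that the limit leaves unreadable from compound 1 to compound 2, and it gives no usable size or direction. No shift beyond the scatter is therefore expected in this assay. The expected change is a 1.2-fold lower number from compound 2 to compound 4 (0.06 log units; within the scatter). Compound 4 is estimated at 12000 nM, with an expected range of 4500 nM to 30000 nM.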

Compound 4, half-maximal inhibitory concentration: 10000 nM
Compound 4: the middle estimate sits 1.2-fold (0.08 log units) above what was measured, and the stated range covers the measured number.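

In this assay, 2,4,6-trimethylphenyl in place of 2,5-dimethylphenyl on a saturated chain carbon bound to an aromatic carbon and a nitrogen on an aromatic ring gives a 1.4-fold lower number from compound 2 to compound 4 (0.14 log units; within the scatter). This change of methyl pattern therefore shows no shift beyond the scatter. With 2,4,6-trimethylphenyl in place of 2-fluorophenyl at this place, the data give a number no higher from compound 1 to compound 4 (the limit leaves the size open). The size of that step and the step from compound 1 to compound 2 cannot be read, and the series still sits at the limit: the limit of > 10000 nM in this assay, at which 2 of the 4 values shown sit.

From the compounds shown here alone, whether an amine or a carboxylic acid on the phenyl ring at this place would move the number beyond the scatter remains open. Going by these compounds, the effect of replacing that ring with a longer chain is also open.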